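Thiophen-2-yl in place of phenyl on the shared core

A few compounds are considered here, and "the series" means these few. Any claim that something is new, unique, unknown or untested is made for them only; others in the source may bear on it.

For the measured compounds named here, in a functional assay on PANC-1 cells (Homo sapiens) for inhibition, read by sulforhodamine B assay, with a stated time of 48 h (on this read-out higher numbers stand for weaker inhibition of growth and lower numbers for stronger inhibition of growth), compound 1 `c1ccc(-c2nc3ncccn3c2CN2CCCC2)cc1` gives 60 nM, the lower of the two numbers so far, and compound 2 `Cc1ccn2c(CN3CCCC3)c(-c3ccccc3)nc2n1` gives 150 nM. Compound 3 `c1csc(-c2nc3ncccn3c2CN2CCCC2)c1` carries thiophen-2-yl in place of phenyl on an aromatic carbon. Going by the values given here, the only measured step, a 2.5-fold higher number from compound 1 to compound 2 (0.40 log units; beyond the scatter), is a different change, methyl in place of hydrogen on an aromatic carbon, so it offers only a rough guide to size. Among the compounds with values here, no measured step replaces the phenyl. A modest step toward a higher number in this assay is expected. The expected shift is a 1.7-fold higher number from compound 1 to compound 3 (0.22 log units; within the scatter). For compound 3 the estimated value is 100 nM, with an expected range of 35 nM to 280 nM.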

Compound 3, concentration for 50% growth inhibition: 680 nM
Estimate against measurement, compound 3: 6.8-fold (0.83 log units) below; measured number above the stated range.
By their numbers in this assay, from the lowest: compound 1; then compound 2; then compound 3.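

In this assay, the aryl place on the shared core proves sensitive to this exchange: thiophen-2-yl for phenyl gives an 11-fold higher number from compound 1 to compound 3 (1.05 log units; beyond the scatter), so phenyl is not freely replaced by this five-membered aromatic ring. The step runs in the same direction as a 2.5-fold higher number from compound 1 to compound 2 (0.40 log units; beyond the scatter), the methyl change made elsewhere on the core. Nothing available explains the loss.

Open, on these data alone, is whether furan-2-yl, thiophen-3-yl or a pyridine ring would behave like thiophen-2-yl. Also open, as far as these compounds go, is whether a substituted phenyl, such as 4-fluorophenyl, would keep the number of compound 1.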